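This account rests on a few compounds, and the source may have more. Where it says the series, first, only, none or still open, it means among the compounds named here.

In a toxicity assay on NIH3T3 cells (Mus musculus) for cytotoxicity, read by resazurin assay (a higher number here means that more compound is needed for the effect, a lower number that less compound is needed), compound 2 (`COC(=O)c1ccc(NCc2cncn2Cc2cccc([N+](=O)[O-])c2)cc1-c1ccccc1`) gives > 10000 nM, which is a limit and not a number. Compound 1 (`CC(=O)c1ccc(NCc2cncn2Cc2ccc(-c3ccccc3)cc2)cc1-c1ccccc1`) likewise gives a limit, > 10000 nM. Compound 3 (`N#Cc1ccc(NCc2cncn2Cc2ccc(-c3ccccc3)cc2)cc1-c1ccccc1`) also gives only a limit, > 1000 nM. The picture so far is therefore (the limit of > 10000 nM in this assay, at which 2 of the 3 values shown sit), and (the limit of > 1000 nM in this assay, at which 1 of the 3 values shown sits). The next compound, compound 4 (`COC(=O)c1ccc(NCc2cncn2Cc2ccccc2Cl)cc1-c1ccccc1`), differs from compound 2 by 2-chlorophenyl in place of 3-nitrophenyl on a saturated chain carbon bound to an aromatic nitrogen. For the measured compounds named here, only one measured step exists, a step that the two limits leave unreadable from compound 1 to compound 3, and it has no readable size. It also concerns cyano in place of acetyl on an aromatic carbon, not the change at issue here. The limit of compound 2 at > 10000 nM is thus the only anchor, and no step beyond the scatter is expected in this assay. The expected step is a step that the limit leaves unreadable from compound 2 to compound 4. Compound 4 is estimated at 12000 nM, with an expected range of 4000 nM to 30000 nM.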

Compound 4, half-maximal effective concentration: 10000 nM
Estimate against measurement, compound 4: 1.2-fold (0.08 log units) above, and the stated range covers the measured number.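

In this assay compound 4 gives 10000 nM, the only actual number among the compounds shown, so the 2-chlorobenzyl group gives a readable value at this place on a saturated chain carbon bound to an aromatic nitrogen. Compound 2 gives > 10000 nM, which is a limit. The change from 3-nitrophenyl to 2-chlorophenyl is therefore a number no higher from compound 2 to compound 4 (the limit leaves the size open), and it cannot be called a gain or a loss in cytotoxicity.

Still open, from the compounds shown here alone, is whether any compound gives a number clearly under the value of compound 4, since most of the values shown remain limits: the limit of > 10000 nM in this assay, at which 2 of the 4 values shown sit. Also open is what a benzyl group carrying an amine or a carboxylic acid, or a longer chain in place of the benzyl group, would give at the same place.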